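This account rests on a few compounds, and the source may have more. Where it says the series, first, only, none or still open, it means among the compounds named here.

Within the data shown here, compound 2 `CC(C)c1nnc2nnc(N3CCCC3)nn12` gives 46800 nM in a functional assay on MCF7 cells (Homo sapiens) for cytotoxicity, read by MTT assay, with a stated time of 72 h (a higher number here means a weaker inhibitor, a lower number a stronger inhibitor), the higher of the two numbers known so far, although its nearest neighbour, compound 1 `Cc1nnc2nnc(N3CCCC3)nn12`, gives 44800 nM, which lies within the scatter of that figure. Among the measured compounds shown here, the single measured step, a 1.0-fold higher number from compound 1 to compound 2 (0.02 log units; within the scatter), came from putting isopropyl in place of methyl on an aromatic carbon. Compound 3 `CCc1nnc2nnc(N3CCCC3)nn12` differs from compound 2 by hydrogen in place of methyl on a saturated chain carbon bound to an aromatic carbon and a saturated chain carbon. Because that step, a 1.0-fold higher number from compound 1 to compound 2 (0.02 log units; within the scatter), stayed within the scatter, compound 3 is expected to show a 1.0-fold lower number from compound 2 to compound 3 (0.02 log units; within the scatter), nothing beyond the scatter. For compound 3 the estimated value is 45000 nM, with a range from 22000 nM to 90000 nM.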

Compound 3, half-maximal inhibitory concentration: 47000 nM
For compound 3 the middle estimate is 1.0-fold (0.02 log units) below the measured one; the measured number falls inside the stated range.
By their numbers in this assay, from the lowest: compounds 1, 2 and 3 (each within the scatter of the next).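

Measured against isopropyl, ethyl gives a 1.0-fold higher number from compound 2 to compound 3 (0.00 log units; within the scatter) in this assay and, measured against methyl, it gives a 1.0-fold higher number from compound 1 to compound 3 (0.02 log units; within the scatter) at the same position. Methyl, ethyl and isopropyl on this carbon therefore cannot be told apart in this read-out, so the flat picture now holds for three groups instead of two. No supporting evidence bears on this result.

The compounds shown leave open whether a phenyl ring, an amine or a carboxylic acid at this position would move the number beyond the scatter.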